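The source may report more compounds than this note shows. Statements on the series, on what has been measured and on what is new or still open speak of the compounds shown alone.

Compound 1 `ClCc1cccc(Cn2cnc3ncnc(Cl)c32)c1` and compound 2 `ClCc1cccc(Cn2cnc3c(Cl)ncnc32)c1` share a benzyl group bearing a chloromethyl substituent, attached to closely related bicyclic cores; the difference between the two cores is not broken down here. In a functional assay on COLO 205 cells (Homo sapiens) for cytotoxicity, read by sulforhodamine B assay, with a stated time of 48 h (a higher number here means a weaker inhibitor of growth, a lower number a stronger inhibitor of growth), compound 1 gives 2630 nM, and compound 2 gives 3090 nM. Compound 3 `ClCc1cccc(Cn2cnc3c(Cl)nc(Cl)nc32)c1` arises from compound 2 by one change, (chloro in place of hydrogen on an aromatic carbon). In this assay compound 3 gives 2230 nM, a step of a 1.4-fold lower number from compound 2 to compound 3 (0.14 log units; within the scatter). Compound 4 `ClCc1cccc(Cn2cnc3nc(Cl)nc(Cl)c32)c1` is related to compound 1 by the same change, (chloro in place of hydrogen on an aromatic carbon), at a place described in identical terms. The step from compound 1 to compound 4 is therefore expected to be similar, about a 1.3-fold lower number from compound 1 to compound 4 (0.12 log units; within the scatter), because compound 3 moved only by a 1.4-fold lower number from compound 2 to compound 3 (0.14 log units; within the scatter) from compound 2. For compound 4 the estimated result is 2000 nM, expected to fall between 900 nM and 4500 nM.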

Compound 4, concentration for 50% growth inhibition: 410 nM
For compound 4 the middle estimate is 4.9-fold (0.69 log units) above the measured one, and the stated range ends above it.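

In this assay, chloro in place of hydrogen on an aromatic carbon, here between two ring nitrogen atoms, gives a 6.4-fold lower number from compound 1 to compound 4 (0.81 log units; beyond the scatter). The same change therefore does not carry over with the same size from one core to the other: the same change on two cores in this assay, a 1.4-fold lower number (0.14 log units; within the scatter) from compound 2 to compound 3 and a 6.4-fold lower number (0.81 log units; beyond the scatter) from compound 1 to compound 4, 4.6-fold (0.67 log units) apart, beyond the scatter of two such steps

Among these compounds, with only two pairs, this shows that the size of the step differs between these two cores, but not why it differs or what the step would be on a further core. The compounds shown leave open whether another group at that place, such as an amine or a methoxy group, would keep the low number of compound 4. They also leave open how a plain methyl group in place of the chloromethyl group would read.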